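Aryl swap on compound 3: expected antiproliferative potency

The source may hold more compounds than are shown below. What is called first, only, known or untested is meant among the compounds shown, and "the series" means these compounds.

Measured so far in a functional assay on PC-3 cells (Homo sapiens) for antiproliferative activity, read by MTT assay, with a stated time of 48 h; a lower number here means a stronger inhibitor, a higher number a weaker inhibitor:
compound 1 `CC1(C)Cc2c(ccc(C(=O)/C=C/c3cn(-c4ccccc4)nc3-c3cccc([N+](=O)[O-])c3)c2OCc2ccccc2)O1` gives > 100000 nM, which is a limit of the assay and not a number;
compound 2 `COc1ccc(-c2nn(-c3ccccc3)cc2/C=C/C(=O)c2ccc(O)c3c2OC(C)(C)C3)cc1` gives 20800 nM;
compound 3 `COc1ccc(-c2nn(-c3ccccc3)cc2/C=C/C(=O)c2ccc(OCc3ccccc3)c3c2OC(C)(C)C3)cc1` gives 7900 nM.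

Compound 3 holds the lowest of the two numbers, with compound 2 nearest; the step of a 2.6-fold lower number from compound 2 to compound 3 (0.42 log units; beyond the scatter) is beyond the scatter. Compound 1 stands at the limit (the limit of > 100000 nM in this assay, at which 1 of the 3 values shown sits).

Compound 4 `CC1(C)Cc2c(OCc3ccccc3)ccc(C(=O)/C=C/c3cn(-c4ccccc4)nc3-c3cccc([N+](=O)[O-])c3)c2O1` differs from compound 3 in one place: 3-nitrophenyl in place of 4-methoxyphenyl on an aromatic carbon. Going by the values given here, no measured step covers this change. Among the compounds with values here, the only measured step, a 2.6-fold lower number from compound 2 to compound 3 (0.42 log units; beyond the scatter), concerns the benzyl on the oxygen and says nothing about the group on the five-membered ring. Compound 1 carries the same 3-nitrophenyl as compound 4 but also differs from it in a second place, and sits at the limit (the limit of > 100000 nM in this assay, at which 1 of the 3 values shown sits); this is a loose hint only. The expected step of a 2.5-fold higher number from compound 3 to compound 4 (0.40 log units; beyond the scatter) is therefore towards a higher number, with wide uncertainty. For compound 4 the estimate in this assay is 20000 nM, within 5000 nM to 80000 nM.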

Compound 4, half-maximal inhibitory concentration: 5900 nM
Estimate against measurement, compound 4: 3.4-fold (0.53 log units) above; measured number inside the range.
By their numbers in this assay, from the lowest: compounds 4 and 3 (each within the scatter of the next); then compound 2. At a limit, above all of these: compound 1.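

In this assay, 3-nitrophenyl in place of 4-methoxyphenyl on this aromatic carbon of the five-membered ring gives a 1.3-fold lower number from compound 3 to compound 4 (0.13 log units; within the scatter), so the two aryl groups cannot be told apart at this position. Compound 4 also shows that a 3-nitrophenyl here is compatible with a measured value in this assay, which compound 1 alone did not show. Compound 1, which carries the same 3-nitrophenyl, stands at a limit and not at a number: the limit of > 100000 nM in this assay, at which 1 of the 4 values shown sits.

The compounds shown do not separate the group from its placement on the aryl ring, which a 4-nitrophenyl or a 3-methoxyphenyl would address. Also open, on these data alone, is how this position responds to an aryl ring bearing an amine or a carboxylic acid, or to a simple alkyl chain in place of the aryl ring.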